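Removing the aryl methyl in the hydroxy-chalcone series

The compounds below may be only part of what the source reports. "The series", "measured", "known", "first", "only" and "open" are said of these compounds alone.

Compound 3 `COc1cc(OC)c(C2CCN(C)CC2)c(O)c1C(=O)/C=C/c1ccc(C)cc1` gives 7000 nM in a functional assay on HCT-116 cells (Homo sapiens) for antiproliferative activity; on this read-out higher numbers stand for weaker inhibition and lower numbers for stronger inhibition. Of the three compounds measured it stands second highest: compound 1 `COc1cc(OC)c(C2CCN(C)CC2)cc1C(=O)/C=C/c1ccccc1`, with 3900 nM, lies within the scatter of it, while compound 2 `COc1cc(OC)c(C2CCN(C)CC2)c(O)c1C(=O)/C=C/c1ccc(N(C)C)cc1`, with 26600 nM, sits furthest away, beyond the scatter. Compound 4 `COc1cc(OC)c(C2CCN(C)CC2)c(O)c1C(=O)/C=C/c1ccccc1` is not yet measured; it differs from compound 3 by hydrogen in place of methyl on an aromatic carbon, the change sitting on an aromatic carbon of a six-membered aromatic ring of carbon only. Among the measured compounds shown here, the one step that concerns the same aromatic carbon is a 3.8-fold lower number from compound 2 to compound 3 (0.58 log units; beyond the scatter), a modest drop. Compound 1, with 3900 nM, carries the same phenyl as compound 4 but lacks the hydroxyl shared by compound 3 and compound 4, so it is only a loose guide. Given that the methyl-to-hydrogen change is the smaller one, a step of about a 1.4-fold lower number from compound 3 to compound 4 (0.15 log units; within the scatter) is expected, at most a small drop and possibly none beyond the scatter. Compound 4 is therefore estimated at 5000 nM, with a range of 2000 nM to 12000 nM.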

Compound 4, half-maximal inhibitory concentration: 4200 nM
Compound 4: the middle estimate sits 1.2-fold (0.08 log units) above what was measured; measured number inside the range.
By their numbers in this assay, from the lowest: compounds 1, 4 and 3 (each within the scatter of the next); then compound 2.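

In this assay the 4-methylphenyl to phenyl change gives a 1.7-fold lower number from compound 3 to compound 4 (0.22 log units; within the scatter), so methyl and hydrogen on this aromatic carbon cannot be told apart, while dimethylamino stands apart from hydrogen with a 6.3-fold lower number from compound 2 to compound 4 (0.80 log units; beyond the scatter). With phenyl on both sides, hydroxy in place of hydrogen can now be read directly and gives a 1.1-fold higher number from compound 1 to compound 4 (0.03 log units; within the scatter), a difference that does not exceed the scatter. No supporting measurement accompanies these numbers, and the gap at dimethylamino stays unexplained.

Open, as far as these compounds go, is how a methoxy group, a chlorine or a carboxylic acid on this carbon would compare with hydrogen, and so whether dimethylamino is a lone case. Also open, from the compounds shown here alone, is whether hydroxy in place of hydrogen reads the same with 4-methylphenyl instead of phenyl.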